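Amine chain change from compound 3 to compound 4

The source may report more compounds than this note shows. Statements on the series, on what has been measured and on what is new or still open speak of the compounds shown alone.

In a functional assay on HL60/MX2 cells (Homo sapiens) for antiproliferative activity, read by MTT assay, with a stated time of 48 h (a lower number here means a stronger inhibitor, a higher number a weaker inhibitor), compound 3 `CCN(CC)CCn1c(N)c(-c2nc3ccccc3n2C)c2nc(C#N)c(C#N)nc21` gives 3250 nM. The two other measured compounds are compound 1 `CN(C)CCCCn1c(N)c(-c2nc3ccccc3o2)c2nc(C#N)c(C#N)nc21` at 960 nM and compound 2 `CN(C)CCCCn1c(N)c(-c2nc3ccccc3s2)c2nc(C#N)c(C#N)nc21` at 2140 nM. Compound 3 sits within the scatter of compound 2 and beyond the scatter on the weaker side of compound 1.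

Compound 4 `CN(C)CCCCn1c(N)c(-c2nc3ccccc3n2C)c2nc(C#N)c(C#N)nc21` differs from compound 3 only in the chain: 2-(dimethylamino)ethyl in place of diethylamino on a saturated chain carbon, two bonds along the chain from an aromatic nitrogen. In words, this is 2-(dimethylamino)ethyl in place of diethylamino on a saturated chain carbon, two bonds along the chain from an aromatic nitrogen. Cut one bond further out, it reads 2-(diethylamino)ethyl to 4-(dimethylamino)butyl.

For the measured compounds named here, the only measured step, a 2.2-fold higher number from compound 1 to compound 2 (0.35 log units; beyond the scatter), puts 1,3-benzothiazol-2-yl in place of 1,3-benzoxazol-2-yl on an aromatic carbon and leaves the chain untouched. Going by the values given here, no measured step therefore isolates the chain change. Its bearing is indirect: compound 1 and compound 2 already carry the 4-(dimethylamino)butyl chain, but with other aromatic groups, and neither value lies beyond the scatter on the weaker side of compound 3.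

A small move toward a lower number is expected, not clearly beyond the scatter, with the estimated change being a 1.6-fold lower number from compound 3 to compound 4 (0.21 log units; within the scatter). The estimate for compound 4 is 2000 nM, with an expected range of 800 nM to 5000 nM.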

Compound 4, half-maximal inhibitory concentration: 2580 nM
Compound 4: the middle estimate sits 1.3-fold (0.11 log units) below what was measured, and the stated range covers the measured number.
By their numbers in this assay, from the lowest: compound 1; then compounds 2, 4 and 3 (each within the scatter of the next).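

In this assay, with 1-methyl-1H-benzimidazol-2-yl held fixed, the exchange of 2-(diethylamino)ethyl for 4-(dimethylamino)butyl gives a 1.3-fold lower number from compound 3 to compound 4 (0.10 log units; within the scatter) and so does not tell these two chains apart. For the compounds shown here, with 4-(dimethylamino)butyl now held fixed, the aromatic group can be read for the first time against 1-methyl-1H-benzimidazol-2-yl: a 1.2-fold higher number from compound 2 to compound 4 (0.08 log units; within the scatter) does not separate it from 1,3-benzothiazol-2-yl, while a 2.7-fold higher number from compound 1 to compound 4 (0.43 log units; beyond the scatter) does separate it from 1,3-benzoxazol-2-yl. Among the three compounds carrying this chain, compound 1 therefore stands apart on the lower side, and neither compound 2 nor compound 4 goes against that, though the pattern rests on these three alone.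

Open, from the compounds shown here alone, is whether the chain exchange would also read flat with 1,3-benzoxazol-2-yl in place, and whether 3-(dimethylamino)propyl or a chain ending in a morpholine or a pyrrolidine would stay within the same range. No supporting measurement accompanies these numbers that could account for the position of compound 1 or for the flat chain step.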